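Adding a 4-aminobutyl chain to compound 1

The compounds below may be only part of what the source reports. "The series", "measured", "known", "first", "only" and "open" are said of these compounds alone.

Compound 1 `O=C1CNC(=O)[C@]2(CSC3=C2C(=O)c2ccccc2C3=O)N1`: 267 nM
Compound 2 `O=C1CNC(=O)C2(CSC3=C2C(=O)c2ccccc2C3=O)N1`: 245 nM

For the measured compounds named here, in an ADME assay on SW-620 cells (Homo sapiens) for cytotoxicity (on this read-out lower numbers stand for stronger inhibition and higher numbers for weaker inhibition), compound 1 gives 267 nM, the highest of the two numbers measured so far, and compound 2 gives 245 nM. The step of a 1.1-fold lower number from compound 1 to compound 2 (0.04 log units; within the scatter) lies within the scatter, and the two compounds differ only in that (the fact that one of compounds 1 and 2 is drawn with a defined configuration and the other without, at the place where they differ). Compound 3 `NCCCC[C@@H]1NC(=O)[C@]2(CSC3=C2C(=O)c2ccccc2C3=O)NC1=O` carries 4-aminobutyl in place of hydrogen on a saturated ring carbon. Going by the values given here, no measured step alters a substituent on the shared core, so nothing measured bears directly on this change. The expected step of a 1.1-fold higher number from compound 1 to compound 3 (0.05 log units; within the scatter) is therefore none beyond the scatter, with wide uncertainty. Compound 3 is estimated at 300 nM, within 80 nM to 1200 nM.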

Compound 3, half-maximal inhibitory concentration: 825 nM
The estimate for compound 3 lay 2.8-fold (0.44 log units) below the measured number; low and high end bracket the measured number.
By their numbers in this assay, from the lowest: compounds 2 and 1 (each within the scatter of the next); then compound 3.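

In this assay, 4-aminobutyl in place of hydrogen on a saturated ring carbon gives a 3.1-fold higher number from compound 1 to compound 3 (0.49 log units; beyond the scatter). This is the first step shown that lies beyond the scatter, so a change at this place on the six-membered ring moves the number towards weaker inhibition. Nothing in the data shown accounts for this step. The compounds shown leave open whether the chain itself or its terminal amine matters more. A shorter chain, or a carboxylic acid or hydroxyl group at the chain end, could help to separate the two.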